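Swapping a Butyl Tail for Methoxy on a Growth Inhibitor

A few compounds are considered here, and "the series" means these few. Any claim that something is new, unique, unknown or untested is made for them only; others in the source may bear on it.

Compound 1 `Cc1ccc(-c2cc(N3CCC(CCNS(N)(=O)=O)CC3)ncn2)cc1` and compound 2 `CCCCc1ccc(-c2cc(N3CCC(CCNS(N)(=O)=O)CC3)ncn2)cc1` share one core and differ only in the group on the six-membered aromatic ring of carbon only. In a functional assay on MCF7 cells (Homo sapiens) for antiproliferative activity, read by sulforhodamine B assay, with a stated time of 48 h (a higher number here means a weaker inhibitor of growth, a lower number a stronger inhibitor of growth), compound 1 gives 47500 nM, while compound 2 gives 11300 nM, the lower of the two numbers; the step of a 4.2-fold lower number from compound 1 to compound 2 (0.62 log units; beyond the scatter) lies beyond the scatter. Compound 3 `COc1ccc(-c2cc(N3CCC(CCNS(N)(=O)=O)CC3)ncn2)cc1` carries a (methoxy in place of butyl on an aromatic carbon). Among the compounds with values here, the one measured step shows a longer chain there lowering the number, so shrinking it to a short acceptor-bearing group is expected to raise the number again, although no methoxy has been measured. The expected step is a 2.7-fold higher number from compound 2 to compound 3 (0.42 log units; beyond the scatter). Compound 3 is therefore estimated at 30000 nM, with a range from 10000 nM to 90000 nM.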

Compound 3, concentration for 50% growth inhibition: 56600 nM
Estimate against measurement, compound 3: 1.9-fold (0.28 log units) below, and the stated range covers the measured number.
By their numbers in this assay, from the lowest: compound 2; then compounds 1 and 3 (each within the scatter of the next).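

In this assay, methoxy in place of butyl gives a 5.0-fold higher number from compound 2 to compound 3 (0.70 log units; beyond the scatter), so the lower number of compound 2 does not carry over to this short oxygen-bearing group. Methoxy in place of methyl gives a 1.2-fold higher number from compound 1 to compound 3 (0.08 log units; within the scatter), which means these two small groups cannot be told apart here and only butyl stands apart among the three. Nothing available gives a reason for this difference. Still open, as far as these compounds go, is whether a shorter chain such as ethyl or propyl already lowers the number, or whether it takes the full butyl. From the compounds shown here alone, how an amine or a hydroxyl would behave at this position also remains unknown.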